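Aryl Replacements on the Hexynyl Lead in HL-60 Antiproliferation

A few compounds are considered here, and "the series" means these few. Any claim that something is new, unique, unknown or untested is made for them only; others in the source may bear on it.

Compound 1 `CCCCC#Cc1cc([C@@H]2O[C@H](CO)[C@@H](O)[C@H]2O)n2ncnc(N)c12` gives 400 nM in a functional assay on HL-60 cells (Homo sapiens) for antiproliferative activity, with a stated time of 72 h; on this read-out higher numbers stand for weaker inhibition and lower numbers for stronger inhibition. Among the compounds with values here, compound 2 `Nc1ncnn2c([C@@H]3O[C@H](CO)[C@@H](O)[C@H]3O)cc(-c3ccc(Cl)cc3)c12` gives 37900 nM in this assay, and it stands highest of the two numbers so far, its nearest neighbour being compound 1. Within the data shown here, the single measured step, a 95-fold higher number from compound 1 to compound 2 (1.98 log units; beyond the scatter), is large and beyond the scatter.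

Compound 3 `Nc1ncnn2c([C@@H]3O[C@H](CO)[C@@H](O)[C@H]3O)cc(-c3ccccc3F)c12` remains to be measured. It differs from compound 2 by 2-fluorophenyl in place of 4-chlorophenyl on an aromatic carbon. Among the measured compounds shown here, no measured step bears directly on an exchange of one substituted phenyl for another: the step from compound 1 to compound 2 compares an alkyne with an aryl group, not two aryl groups, so it only sets the position of compound 2 as the starting point. With nothing to anchor the direction, the expected step is either none beyond the scatter or a small one in either direction. Compound 3 is therefore expected to stay near compound 2 in this assay, and the estimated step is a 1.5-fold lower number from compound 2 to compound 3 (0.18 log units; within the scatter). Compound 3 is estimated at 25000 nM, within a range from 6000 nM to 100000 nM.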

Compound 3, half-maximal inhibitory concentration: > 100000 nM
Compound 3: only a limit was reported (the forecaster's own chance of this, stated with the estimate: 15%); middle value at least 4.0-fold (0.60 log units) from the limit.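

In this assay compound 3 gives only a limit of the assay, not a number: the limit of > 100000 nM in this assay, at which 1 of the 3 values shown sits.

Even so, the exchange of one substituted phenyl for another at this aromatic carbon can be read as an at least 2.6-fold higher number from compound 2 to compound 3 (0.42 log units; beyond the scatter), so the identity of the aryl group still moves the read-out beyond the scatter, although the full size of the step stays unknown. A second aryl replacement of hex-1-yn-1-yl gives an at least 250-fold higher number from compound 1 to compound 3 (2.39 log units; beyond the scatter), so both aryl groups shown, in compound 2 and compound 3, sit far on the weak side of the hexynyl lead, with no compound going against this among the three.

Compound 3 changes both the halogen and its place on the phenyl ring, so the compounds shown do not separate these two changes, which 2-chlorophenyl and 4-fluorophenyl groups would do. Also open, from the compounds shown here alone, is how unsubstituted phenyl, a shorter alkyne such as but-1-yn-1-yl, or a saturated hexyl chain would read at this position.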